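This account rests on a few compounds, and the source may have more. Where it says the series, first, only, none or still open, it means among the compounds named here.

Measured so far:
compound 1 `O=c1c([C@@H]2C[C@H](c3ccccc3)ON2c2ccccc2)coc2ccc(F)cc12` — in a functional assay on Caco-2 cells (Homo sapiens) for inhibition, read by sulforhodamine B assay, with a stated time of 48 h (on this read-out lower numbers stand for stronger inhibition and higher numbers for weaker inhibition), compound 1 gives 60000 nM
compound 2 `COC(=O)[C@@]1(C)C[C@@H](c2coc3ccc(C)cc3c2=O)N(c2ccccc2)O1` — in this assay compound 2 gives 19700 nM
compound 3 `NC(=O)[C@H]1C[C@@H](c2coc3ccccc3c2=O)N(c2ccccc2)O1` — in this assay compound 3 gives only a limit, > 60000 nM, not a number

Among the two numbers, compound 1 stands highest; the nearest, compound 2, is lower by a margin beyond the usual scatter. The value of compound 3 is a limit of the assay, (the limit of > 60000 nM in this assay, at which 1 of the 3 values shown sits), and is left aside as a number. Within the data shown here, no pair of the measured compounds differs in a single place, so no measured step is at hand.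

Compound 4 `O=c1c([C@@H]2C[C@H](c3ccccc3)ON2c2ccccc2)coc2ccc(Br)cc12` differs from compound 1 in one place: bromo in place of fluoro on an aromatic carbon. With nothing comparable measured, the step in this assay is expected to be small, at most a modest lowering of the number, and quite possibly none beyond the scatter, with a real chance that only a limit is returned. Compound 4 is expected at 40000 nM, between 15000 nM and 120000 nM, which corresponds to an expected 1.5-fold lower number from compound 1 to compound 4 (0.18 log units; within the scatter).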

Compound 4, half-maximal inhibitory concentration: > 60000 nM
Compound 4 was reported as a limit; the forecaster's own chance of this, stated with the estimate: 35%; at least 1.5-fold (0.17 log units) between middle value and limit.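

In this assay, bromo in place of fluoro on an aromatic carbon gives a number no lower from compound 1 to compound 4 (the limit leaves the size open). Among these compounds, this is the first single-place change, and it shows that this exchange at this position brings no lowering of the number, though the size of any rise cannot be read. Compound 4 now sits at the same limit as compound 3: the limit of > 60000 nM in this assay, at which 2 of the 4 values shown sit.

From the compounds shown here alone, whether the change from fluoro to bromo has any real effect in this assay remains open, as does the actual number for compound 4. Also open, going by these compounds, is whether a different group on this aromatic carbon, such as an amine or a methoxy group, would move the number below that of compound 1.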